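The source may report more compounds than this note shows. Statements on the series, on what has been measured and on what is new or still open speak of the compounds shown alone.

Measured so far:
compound 1 `Cn1nc(-c2ccc(OCC34CCC(O)(CC3)CC4)c(F)c2)c2cnc(N)nc21` — 75 nM
compound 2 `Cn1nc(-c2ccc(OC[C@H]3CC[C@@H](N)CC3)c(F)c2)c2cnc(N)nc21` — 20 nM

In an assay on THP-1 cells for antagonist activity at Toll-like receptor 8 (Homo sapiens) (a lower number here means a stronger inhibitor, a higher number a weaker inhibitor), compound 2 stands lowest of the two numbers; its nearest neighbour is compound 1, and the step of a 3.8-fold lower number from compound 1 to compound 2 (0.57 log units; beyond the scatter) lies beyond the scatter. Compound 3 `Cn1nc(-c2ccc(OCCCC3CCNCC3)c(F)c2)c2cnc(N)nc21` is not yet measured. It differs from compound 2 by 2-(piperidin-4-yl)ethyl in place of 4-aminocyclohexyl on a saturated chain carbon bound to an oxygen on an aromatic ring. Among the measured compounds shown here, only the step from compound 1 to compound 2 bears on this change, and it shows that the amine-bearing ring is tolerated well. Compound 3 is expected to sit near compound 2 or somewhat higher, a step of a 2.0-fold higher number from compound 2 to compound 3 (0.30 log units; within the scatter) in this assay. The estimate for compound 3 is 40 nM, with a range from 12 nM to 130 nM.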

Compound 3, half-maximal inhibitory concentration: 26 nM
Beside the measured number, compound 3's estimate is 1.5-fold (0.19 log units) above it; measured number inside the range.
By their numbers in this assay, from the lowest: compounds 2 and 3 (each within the scatter of the next); then compound 1.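

In this assay, 2-(piperidin-4-yl)ethyl in place of 4-aminocyclohexyl gives a 1.3-fold higher number from compound 2 to compound 3 (0.11 log units; within the scatter), so at this position a nitrogen within the ring on a longer chain reads the same as an amine on the ring. Compared with the group of compound 1, the new group gives a 2.9-fold lower number from compound 1 to compound 3 (0.46 log units; beyond the scatter), a step beyond the scatter like the one seen for compound 2. No evidence on the cause of these numbers is at hand. The compounds shown leave open how a 1-methylpiperidin-4-yl group or a carboxylic acid at the end of the chain would read, and whether a shorter chain to the piperidine would hold the number.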